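A Smaller Amine on the Side Chain

The source may hold more compounds than are shown below. What is called first, only, known or untested is meant among the compounds shown, and "the series" means these compounds.

Compound 1 `COc1cc(C(=O)N2CCCC(N(C)C)c3sccc32)ccc1NC(=O)c1ccccc1-c1ccccc1` and compound 2 `O=C(Nc1ccc(C(=O)N2CCCN(CCN3CCCC3)c3sccc32)cc1)c1ccccc1-c1ccccc1` share one core and differ only in the side chain on the ring. In an assay on adrenal medulla for inhibition of Vasopressin V2 receptor (Rattus norvegicus), read by radioligand binding (a lower number here means a stronger inhibitor, a higher number a weaker inhibitor), compound 1 gives 10 nM. In this assay compound 2 gives 10 nM, level with compound 1 within the scatter. Compound 3 `CN(C)CCN1CCCN(C(=O)c2ccc(NC(=O)c3ccccc3-c3ccccc3)cc2)c2ccsc21` differs from compound 2 in one place: dimethylamino in place of pyrrolidin-1-yl on a saturated chain carbon, two bonds along the chain from a nitrogen on an aromatic ring in a ring. For the measured compounds named here, no measured pair shows this kind of change here. The step of no change at the digits printed from compound 2 to compound 3 (within the scatter) is expected to stay within the scatter. In this assay compound 3 is estimated at 10 nM, between 4 nM and 30 nM.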

Compound 3, half-maximal inhibitory concentration: 20 nM
Beside the measured number, compound 3's estimate is 2.0-fold (0.30 log units) below it; the range from low to high includes it.
By their numbers in this assay, from the lowest: compounds 1, 2 and 3 (each within the scatter of the next).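

In this assay, for the compounds shown here, the exchange of pyrrolidin-1-yl for dimethylamino on the saturated chain carbon gives a 2.0-fold higher number from compound 2 to compound 3 (0.30 log units; within the scatter) and so offers the first reading at this position: the amine can lose its ring and two of its heavy atoms with no shift beyond the scatter. Nothing measured here accounts for this result. Still open, as far as these compounds go, is how piperidin-1-yl, morpholin-4-yl or a primary amine would read at this place. From the compounds shown here alone, a carboxylic acid in place of the amine, or a longer chain than 2-(dimethylamino)ethyl, also remains open.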